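The source may hold more compounds than are shown below. What is called first, only, known or untested is meant among the compounds shown, and "the series" means these compounds.

Measured in an in vitro ADME assay on microsomes from liver (Homo sapiens) for metabolic stability, tested at 1 uM; on this read-out higher numbers stand for a longer-lived compound and lower numbers for a shorter-lived compound:
- Compound 1 `CC(C)[C@]1(C(=O)N2C[C@@H]3C[C@H]2CN3C(=O)C(C)(C)C)CC[C@@H](NC2CCOCC2)C1`: > 2 h (a limit)
- Compound 2 `CC(C)[C@]1(C(=O)N2C[C@@H]3C[C@H]2CN3C(=O)C2CC2)CC[C@@H](NC2CCOCC2)C1`: > 2 h (a limit)
- Compound 3 `CC(C)[C@]1(C(=O)N2C[C@@H]3C[C@H]2CN3C(=O)C2CCCC2)CC[C@@H](NC2CCOCC2)C1`: > 2 h (a limit)

Compound 3 gives only a limit and not a number, > 2 h (its standing in the series). Within the data shown here, no ranking can be drawn, since the whole series stands at the limit of > 2 h in this assay, at which 3 of the 3 values shown sit (no compound has a number).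

Compound 4 `CC(OC(=O)N1C[C@@H]2C[C@H]1CN2C(=O)[C@@]1(C(C)C)CC[C@@H](NC2CCOCC2)C1)C(F)(F)F` has not yet been measured. Among the measured compounds shown here, it differs from compound 3 as follows: 1-(trifluoromethyl)ethoxy in place of cyclopentyl on a carbonyl carbon (the group on the carbonyl carbon is the only change).

For the measured compounds named here, three measured steps bear on this place: a step that the two limits leave unreadable from compound 1 to compound 2 and a step that the two limits leave unreadable from compound 1 to compound 3 and a step that the two limits leave unreadable from compound 2 to compound 3 are all exchanges of the group on that carbonyl carbon. Going by the values given here, none of them has a size that can be read, and none of the measured compounds carries 1-(trifluoromethyl)ethoxy, so they give only weak guidance. No step beyond the usual scatter is expected in this assay and no direction can be assigned, so the expected change is a step that the limit leaves unreadable from compound 3 to compound 4 (an estimate, not a measurement). In this assay the estimate for compound 4 is 2.5 h (expected range from 1 h to 6 h).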

Compound 4, half-life: 1.3 h
Beside the measured number, compound 4's estimate is 1.9-fold (0.28 log units) above it; the measured number falls inside the stated range.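

In this assay, compound 4, with 1-(trifluoromethyl)ethoxy on the carbonyl carbon, gives the only value in the series that is a number and not a limit, while the other compounds all stand at that limit: the limit of > 2 h in this assay, at which 3 of the 4 values shown sit.

Exchange of the group at this place can now be given at least a floor, as an at least 1.5-fold lower number from compound 3 to compound 4 (0.18 log units; that floor lies within the scatter), as an at least 1.5-fold lower number from compound 2 to compound 4 (0.18 log units; that floor lies within the scatter) and as an at least 1.5-fold lower number from compound 1 to compound 4 (0.18 log units; that floor lies within the scatter). The steps among compound 1, compound 2 and compound 3 cannot be read, and each new floor lies within the scatter, so the series shows that this change can bring the half-life down to a measurable number but does not establish a real loss.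

Going by these compounds, how far the true half-lives of compound 1, compound 2 and compound 3 lie from their shared limit stays open, and with it the real size of each new step. Also open, on these data alone, is whether the oxygen or the fluorines of the entering group matter, a question that a plain ethoxy group or an isopropoxy group on the same carbonyl carbon would bear on.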